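From Compound 2 to Compound 3 in G-361 Cells

The compounds below may be only part of what the source reports. "The series", "measured", "known", "first", "only" and "open" are said of these compounds alone.

Compound 2 `OC[C@H]1O[C@@H](n2cnc3c(NCc4c(F)ccc(F)c4F)ncnc32)[C@H](O)[C@@H]1O` gives in a functional assay on G-361 cells (Homo sapiens) for antiproliferative activity, with a stated time of 72 h (on this read-out higher numbers stand for weaker inhibition and lower numbers for stronger inhibition), only a limit, > 166000 nM. Compound 1 `OC[C@H]1O[C@@H](n2cnc3c(NCc4cccc(Br)c4)ncnc32)[C@H](O)[C@@H]1O` likewise reaches only a limit in this assay, > 166000 nM. The step from compound 1 to compound 2 is a step that the two limits leave unreadable from compound 1 to compound 2, so no readable step bears on the next change. Compound 3 `COc1cccc(CNc2ncnc3c2ncn3[C@@H]2O[C@H](CO)[C@@H](O)[C@H]2O)c1O` differs from compound 2 by 2-hydroxy-3-methoxyphenyl in place of 2,3,6-trifluorophenyl on a saturated chain carbon bound to a nitrogen on an aromatic ring. With both shown values sitting at the limit of > 166000 nM in this assay, at which 2 of the 2 values shown sit, neither size nor direction of the coming step can be drawn. Compound 3 is therefore estimated at 166000 nM, from 40000 nM to 500000 nM. The step of a number no higher from compound 2 to compound 3 (the limit leaves the size open) is expected to stay within the scatter.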

Compound 3, half-maximal inhibitory concentration: 148000 nM
Compound 3: the middle estimate sits 1.1-fold (0.05 log units) above what was measured; the range from low to high includes it.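

For the compounds shown here, at this place, on a saturated chain carbon bound to a nitrogen on an aromatic ring, 2-hydroxy-3-methoxyphenyl gives the first reading in this assay that is a number and not a limit. Against the two earlier groups, this yields an at least 1.1-fold lower number from compound 2 to compound 3 (0.04 log units; that floor lies within the scatter) and an at least 1.1-fold lower number from compound 1 to compound 3 (0.04 log units; that floor lies within the scatter). Neither floor shows a gain beyond the scatter, and most values still sit at the edge of what the assay reads: the limit of > 166000 nM in this assay, at which 2 of the 3 values shown sit.

From the compounds shown here alone, the true size of either step stays open. So does whether an amine or a carboxylic acid at this place would bring the number clearly lower.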